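The source may report more compounds than this note shows. Statements on the series, on what has been measured and on what is new or still open speak of the compounds shown alone.

Measured so far: compound 1 `CCC1CC=CC(=O)O1` and compound 2 `C=CCCC1CC=CC(=O)O1`.

In a functional assay on MCF7 cells (Homo sapiens) for cytotoxicity, read by MTT assay, with a stated time of 72 h (a lower number here means a stronger inhibitor, a higher number a weaker inhibitor), compound 1 gives only a limit, > 100 ug/mL. In this assay compound 2 also gives only a limit, > 100 ug/mL. The step that the two limits leave unreadable from compound 1 to compound 2 therefore cannot be sized. Compound 2 stands at the limit of > 100 ug/mL in this assay, at which 2 of the 2 values shown sit.

Compound 3 `C=CCOCC1CC=CC(=O)O1` differs by allyloxy in place of allyl on a saturated chain carbon bound to a saturated ring carbon. Among the measured compounds shown here, no measured step bears on this change, and the one pair in hand yields no readable size. The step that the limit leaves unreadable from compound 2 to compound 3 is expected to be none beyond the scatter. The estimate for compound 3 is 150 ug/mL, ranging from 60 ug/mL to 400 ug/mL, most probably reported again as a limit.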

Compound 3, half-maximal inhibitory concentration: 44.6 ug/mL
Estimate against measurement, compound 3: 3.4-fold (0.53 log units) above; measured number below the stated range.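

In this assay, the saturated chain carbon bound to a saturated ring carbon now gives a readable change: allyloxy brings an at least 2.2-fold lower number from compound 2 to compound 3 (0.35 log units; beyond the scatter) and an at least 2.2-fold lower number from compound 1 to compound 3 (0.35 log units; beyond the scatter). Both sizes are minimum sizes, and the step from compound 1 to compound 2 cannot be read. Only compound 3 has left the limit of the assay: the limit of > 100 ug/mL in this assay, at which 2 of the 3 values shown sit.

From the compounds shown here alone, the true size of either step stays open. Also open, going by these compounds, is whether the oxygen or the extra chain atom carries the change, and a longer chain without oxygen or an amine in place of the oxygen would bear on that.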